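The source may report more compounds than this note shows. Statements on the series, on what has been measured and on what is new or still open speak of the compounds shown alone.

Series notes. Compound 1 `O=c1cc(CNCc2ccccc2I)oc2ccc(O)c(O)c12` and compound 2 `O=c1cc(CNCc2ccc(I)cc2)oc2ccc(O)c(O)c12` share the same core and differ only in where the iodo sits on the benzyl ring bound to the amine nitrogen. In an ADME assay on Huh-7 cells (Homo sapiens) for cytotoxicity (a higher number here means that more compound is tolerated, a lower number that less compound is tolerated), compound 1 gives 87300 nM. In this assay, within the data shown here, compound 2 gives 41700 nM, the lowest of the two numbers so far; its only neighbour is compound 1, and the move between them amounts to a 2.1-fold lower number from compound 1 to compound 2 (0.32 log units; beyond the scatter), a modest step that lies beyond the scatter.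

Compound 3 `Cc1ccc(CNCc2cc(=O)c3c(O)c(O)ccc3o2)cc1` is the next member: methyl in place of iodo on an aromatic carbon, the same difference read one bond further out being 4-iodophenyl to 4-methylphenyl. Among the measured compounds shown here, no measured step exchanges one group for another at this position; the single step recorded, a 2.1-fold lower number from compound 1 to compound 2 (0.32 log units; beyond the scatter), only moves the iodo from one aromatic carbon to another and gives no direct guide to swapping iodo for methyl. With nothing in the data bearing on this exchange, the expectation for compound 3 in this assay is a step of a 1.2-fold higher number from compound 2 to compound 3 (0.08 log units; within the scatter), that is, none beyond the scatter. Compound 3 is therefore estimated at 50000 nM, with a range from 22000 nM to 110000 nM.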

Compound 3, half-maximal cytotoxic concentration: > 100000 nM
Compound 3 was reported as a limit (the forecaster's own chance of this, stated with the estimate: 10%); middle value at least 2.0-fold (0.30 log units) from the limit.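

In this assay, among these compounds, the exchange of iodo for methyl on an aromatic carbon, para to a large group, gives the first step that replaces the group rather than moving it: an at least 2.3-fold higher number from compound 2 to compound 3 (0.37 log units; beyond the scatter). Compared with the 2-iodophenyl compound, the 4-methylphenyl change gives an at least 1.1-fold higher number from compound 1 to compound 3 (0.05 log units; that floor lies within the scatter), so no order can be stated for that pair, while compound 2 now holds the lowest number of the three, with its steps to both others beyond the scatter. The reading for compound 3 is a limit and not a number, so both steps from it are floors: the limit of > 100000 nM in this assay, at which 1 of the 3 values shown sits.

From the compounds shown here alone, it remains open whether the shift at this position is tied to iodo in particular or would appear with other groups there, such as a chloro, a methoxy or a carboxylic acid on the same aromatic carbon. Also open, going by these compounds, are how 2-methylphenyl would compare with 4-methylphenyl and how a longer chain on the amine nitrogen would read in this assay.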